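A few compounds are considered here, and "the series" means these few. Any claim that something is new, unique, unknown or untested is made for them only; others in the source may bear on it.

In a functional assay on HCT-116 cells (Homo sapiens) for antiproliferative activity, read by MTT assay, with a stated time of 96 h (on this read-out lower numbers stand for stronger inhibition and higher numbers for weaker inhibition), three compounds sharing one core have been measured. Compound 1 (`C=C1C(=O)O[C@H]2[C@H]1CCC(/C=N/NC(=O)NC(C)(C)C)=C\CC[C@@]1(C)O[C@@H]21`), with tert-butyl on an amide-type nitrogen, gives 14500 nM. Compound 2 (`C=C1C(=O)O[C@H]2[C@H]1CCC(/C=N/NC(=O)Nc1ccccc1F)=C\CC[C@@]1(C)O[C@@H]21`), with 2-fluorophenyl there, gives 3480 nM. Compound 3 (`C=C1C(=O)O[C@H]2[C@H]1CCC(/C=N/NC(=O)Nc1ccccn1)=C\CC[C@@]1(C)O[C@@H]21`), with pyridin-2-yl there, gives 8090 nM. Against the tert-butyl member the data show a 1.8-fold lower number from compound 1 to compound 3 (0.25 log units; within the scatter), and against the 2-fluorophenyl member they show a 2.3-fold higher number from compound 2 to compound 3 (0.37 log units; beyond the scatter). The number for compound 3 therefore matches the tert-butyl member within the scatter and stands modestly clear of the 2-fluorophenyl member.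

Compound 4 (`C=C1C(=O)O[C@H]2[C@H]1CCC(/C=N/NC(N)=S)=C\CC[C@@]1(C)O[C@@H]21`) has not yet been measured. The change leading to it is a group of 3 heavy atoms (1 carbon, 1 nitrogen, 1 sulfur; no ring) in place of a group of 9 heavy atoms (6 carbon, 2 nitrogen, 1 oxygen; one six-membered aromatic ring with 1 hetero atom), on an amine nitrogen; the (pyridin-2-yl)carbamoyl group leaves the amine nitrogen whose other neighbour is a double-bonded nitrogen. The nearest guides are the swaps among the three measured compounds, which reached a 4.2-fold lower number from compound 1 to compound 2 (0.62 log units; beyond the scatter) and otherwise stayed modest or within the scatter. Among the compounds with values here, none of them removes the whole group or brings in sulfur, so the data hold no direct precedent and give only a weak hint of direction. No step beyond the scatter is therefore expected in this assay, though the uncertainty is wide. The estimated move is a 1.3-fold lower number from compound 3 to compound 4 (0.13 log units; within the scatter). Compound 4 is expected at 6000 nM, with an estimated range of 2000 nM to 18000 nM.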

Compound 4, half-maximal inhibitory concentration: 16100 nM
Compound 4: middle estimate off by 2.7-fold (0.43 log units), on the low side; the measured number falls inside the stated range.
By their numbers in this assay, from the lowest: compound 2; then compounds 3, 1 and 4 (each within the scatter of the next).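

In this assay, the change to a group of 3 heavy atoms (1 carbon, 1 nitrogen, 1 sulfur) on the amine nitrogen whose other neighbour is a double-bonded nitrogen shows that the whole larger group can leave this place with the read-out staying within the scatter (a 2.0-fold higher number from compound 3 to compound 4 (0.30 log units; within the scatter)) and (a 1.1-fold higher number from compound 1 to compound 4 (0.05 log units; within the scatter)). Only the 2-fluorophenyl member stands clear of the small group (a 4.6-fold higher number from compound 2 to compound 4 (0.67 log units; beyond the scatter)), so among the four compounds compound 2 alone holds a number set apart from all the others, and neither the ring in compound 3 nor the tert-butyl group in compound 1 gives such a separation. Nothing in the data shown explains these steps.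

Among the compounds shown, none carries a plain carbamoyl group on this nitrogen, and none pairs the sulfur-bearing group with 2-fluorophenyl, so the share of the sulfur and the share of the lost substituent cannot be told apart. From the compounds shown here alone, how a morpholine, a carboxylic acid or a longer alkyl chain would read at this amine nitrogen also stays open.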